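Swapping an Ester for an Oxadiazole

This account rests on a few compounds, and the source may have more. Where it says the series, first, only, none or still open, it means among the compounds named here.

In a functional assay on MOLT-4 cells (Homo sapiens) (a lower number here means a stronger inhibitor, a higher number a weaker inhibitor), compound 1, `O=C(O)c1nn([C@@H]2O[C@H](CO)[C@@H](O)[C@H]2O)cc1I`, gives > 300000 nM, which is a limit and not a number. For the measured compounds named here, compound 2, `CCCCOC(=O)c1nn([C@@H]2O[C@H](CO)[C@@H](O)[C@H]2O)cc1I`, gives 16000 nM, the only exact number so far. Compound 3, `Cc1noc(-c2nn([C@@H]3O[C@H](CO)[C@@H](O)[C@H]3O)cc2I)n1`, keeps the shared core but replaces the ester: 3-methyl-1,2,4-oxadiazol-5-yl in place of butoxycarbonyl on an aromatic carbon. Like compound 2, compound 3 has no free acid, and the only measured guide is an at least 18-fold lower number from compound 1 to compound 2 (1.27 log units; beyond the scatter). No return to the weakness of the acid is therefore expected in this assay, only a modest shift towards a higher number. The expected change is a 1.9-fold higher number from compound 2 to compound 3 (0.27 log units; within the scatter). For compound 3 the estimate is 30000 nM, with an expected range of 8000 nM to 150000 nM.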

Compound 3, half-maximal inhibitory concentration: 3000 nM
Beside the measured number, compound 3's estimate is 10-fold (1.00 log units) above it; measured number outside the range, below it.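

In this assay, the aromatic carbon that carried the ester also accepts a five-membered aromatic ring: 3-methyl-1,2,4-oxadiazol-5-yl in place of butoxycarbonyl gives a 5.3-fold lower number from compound 2 to compound 3 (0.73 log units; beyond the scatter). In place of carboxy, the same ring gives an at least 100-fold lower number from compound 1 to compound 3 (2.00 log units; beyond the scatter). That second step has only a limit, not a number, at one end, set by compound 1: the limit of > 300000 nM in this assay, at which 1 of the 3 values shown sits.

The compounds shown leave open whether a methyl ester or a simple amide at this carbon would match compound 3. They also leave open whether a longer chain on the oxadiazole would change the number.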